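The compounds below may be only part of what the source reports. "The series", "measured", "known", "first", "only" and "open" are said of these compounds alone.

Compound 1 `CC(=O)n1nc(NC(=O)c2ccccc2)c2c1CN(C(=O)c1cccc([N+](=O)[O-])c1)C2` gives 17300 nM
Compound 2 `CC(=O)n1nc(NC(=O)c2ccccc2)c2c1CN(C(=O)c1cccc(Cl)c1)C2` gives 17400 nM
Compound 3 `CC(=O)n1nc(NC(=O)c2ccccc2)c2c1CN(C(=O)c1ccc([N+](=O)[O-])cc1)C2` gives 16200 nM

All three values come from a functional assay on HCT-116 cells (Homo sapiens) for cytotoxicity, read by sulforhodamine B assay, with a stated time of 48 h (on this read-out lower numbers stand for stronger inhibition and higher numbers for weaker inhibition), and compound 3 sits level with the other two (a 1.1-fold lower number from compound 1 to compound 3 (0.03 log units; within the scatter); a 1.1-fold lower number from compound 2 to compound 3 (0.03 log units; within the scatter)). Compound 4 `CC(=O)n1nc(NC(=O)c2ccccc2)c2c1CN(C(=O)CCl)C2` carries chloromethyl in place of 4-nitrophenyl on a carbonyl carbon. The nearest evidence is the changes around the aromatic ring: a 1.0-fold higher number from compound 1 to compound 2 (0.00 log units; within the scatter) and the two steps above, all within the scatter. None of them removes that ring, so they fix no firm size or direction for this change. No step beyond the scatter is expected (a 1.2-fold lower number from compound 3 to compound 4 (0.10 log units; within the scatter)), with a wide margin either way. For compound 4 the estimated value is 13000 nM (expected range 4500 nM to 32000 nM).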

Compound 4, half-maximal inhibitory concentration: 4100 nM
The estimate for compound 4 lay 3.2-fold (0.50 log units) above the measured number, and the stated range ends above it.
By their numbers in this assay, from the lowest: compound 4; then compounds 3, 1 and 2 (each within the scatter of the next).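

At the carbonyl carbon bound to the amide-type ring nitrogen, the aromatic groups of compound 1, compound 2 and compound 3 stay level in this assay, so chloromethyl is what separates this position (a 4.0-fold lower number from compound 3 to compound 4 (0.60 log units; beyond the scatter); a 4.2-fold lower number from compound 2 to compound 4 (0.63 log units; beyond the scatter); a 4.2-fold lower number from compound 1 to compound 4 (0.63 log units; beyond the scatter)). All three steps run the same way and are modest, showing that this position responds once the aromatic ring is gone. Nothing available explains the shift.

Going by these compounds, whether the step follows the chlorine or the loss of the ring stays open. A plain methyl, an aminomethyl or a longer chloroalkyl chain at this carbonyl carbon would separate the two.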